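Solubility notes on the series, compound 2 to compound 4

The source may report more compounds than this note shows. Statements on the series, on what has been measured and on what is new or still open speak of the compounds shown alone.

Three compounds have been run in a physicochemical assay for solubility; on this read-out higher numbers stand for higher solubility and lower numbers for lower solubility. Compound 1 `CNC(=O)c1cc(C(=O)NC2CCC2)cn(Cc2ccccc2)c1=O` gives 28 ug/mL. Compound 3 `CNC(=O)c1ccc(=O)n(Cc2ccccc2)c1` reaches only a limit of the assay, >= 108 ug/mL. Compound 2 `CNC(=O)c1cc(C(=O)NC2CC2)cn(Cc2ccc3nc[nH]c3c2)c1=O` likewise reaches only a limit, >= 163 ug/mL. Compound 2 thus stands at the upper bound of the numbers shown, at the limit of >= 163 ug/mL in this assay, at which 1 of the 3 values shown sits. Going by the values given here, compound 3 sits at the other bound, (the limit of >= 108 ug/mL in this assay, at which 1 of the 3 values shown sits), and compound 1 is the single measured number. Compound 4 `CNC(=O)c1cc(C(=O)NC2CC2)cn(CC2CCCCC2)c1=O` is not yet measured; its change from compound 2 is cyclohexyl in place of 1H-benzimidazol-6-yl on a saturated chain carbon bound to an aromatic nitrogen. Among the compounds with values here, no measured step isolates this change. Compound 1 at 28 ug/mL is the nearest measured point for such a change. The step of an at least 6.5-fold lower number from compound 2 to compound 4 (0.81 log units; beyond the scatter) is therefore expected to be a loss beyond the usual scatter. Compound 4 is estimated at 25 ug/mL, within 8 ug/mL to 80 ug/mL.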

Compound 4, solubility: >= 148 ug/mL
Compound 4 gave a limit, no number; the forecaster's own chance of this, stated with the estimate: 10%; middle value at least 5.9-fold (0.77 log units) away from the limit.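

In this assay compound 4 gives only a limit, >= 148 ug/mL. Compound 2 also gives only a limit, >= 163 ug/mL, so no step can be read between compound 2 and compound 4. The compounds shown leave open how far cyclohexyl and 1H-benzimidazol-6-yl lie apart in this assay.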